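This account rests on a few compounds, and the source may have more. Where it says the series, first, only, none or still open, it means among the compounds named here.

Of the compounds shown here, three built on one shared core have been measured in an ADME assay on HeLa cells (Homo sapiens) for inhibition, read by cell counting; a higher number here means a weaker inhibitor, a lower number a stronger inhibitor. Compound 1 `CSc1nc(NCCCCNc2ccnc3cc(Cl)ccc23)c(C#N)c(-c2ccccc2)n1` gives 8500 nM. Compound 2 `CSc1nc(NCCCCNc2ccnc3cc(Cl)ccc23)c(C#N)c(-c2cccc([N+](=O)[O-])c2)n1` gives 1100 nM. Compound 3 `COc1ccc(-c2nc(SC)nc(NCCCCNc3ccnc4cc(Cl)ccc34)c2C#N)cc1` gives 3400 nM, which places it second highest of the three numbers: a 2.5-fold lower number from compound 1 to compound 3 (0.40 log units; beyond the scatter), and a 3.1-fold higher number from compound 2 to compound 3 (0.49 log units; beyond the scatter).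

Compound 4 `COc1ccc(-c2nc(SC)nc(NCCCCNc3ccnc4cc(Cl)ccc34)c2C#N)cc1OC` has not yet been measured in this assay. The change from compound 3 is methoxy in place of hydrogen on an aromatic carbon. Among the measured compounds shown here, two measured steps bear on it. The first is a 7.7-fold lower number from compound 1 to compound 2 (0.89 log units; beyond the scatter), a different group added to the same phenyl ring. The second, closer in kind, is a 2.5-fold lower number from compound 1 to compound 3 (0.40 log units; beyond the scatter), the same sort of change now repeated. On that basis a modest step downward in this assay is expected for compound 4, though the earlier methoxy step was small enough that the new one could also stay within the scatter. The expected step is a 1.7-fold lower number from compound 3 to compound 4 (0.23 log units; within the scatter). For compound 4 the estimated value is 2000 nM, with a range from 800 nM to 5000 nM.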

Compound 4, half-maximal inhibitory concentration: 20000 nM
The estimate for compound 4 lay 10-fold (1.00 log units) below the measured number; measured number outside the range, above it.
By their numbers in this assay, from the lowest: compound 2; then compound 3; then compound 1; then compound 4.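

In this assay a second methoxy, ortho to a methoxy group, does not repeat the first: it gives a 5.9-fold higher number from compound 3 to compound 4 (0.77 log units; beyond the scatter) and so reverses the direction of a 2.5-fold lower number from compound 1 to compound 3 (0.40 log units; beyond the scatter) seen for the first methoxy. The 3,4-dimethoxyphenyl group ends up with a 2.4-fold higher number from compound 1 to compound 4 (0.37 log units; beyond the scatter) against plain phenyl and an 18-fold higher number from compound 2 to compound 4 (1.26 log units; beyond the scatter) against 3-nitrophenyl, which makes compound 4 the weakest inhibitor of the four. On this ring, then, the step for a methoxy depends on what the ring already carries, and one step cannot simply be added to the next.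

Nothing measured here explains this reversal. Going by these compounds, whether an amine or a chlorine in this same place would also raise the number, or whether a methoxy there without its neighbouring methoxy would do so, stays open.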